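Adding a Hydroxy Group Beside an Imine-Linked Aromatic Ring

The source may hold more compounds than are shown below. What is called first, only, known or untested is meant among the compounds shown, and "the series" means these compounds.

Measured so far in an ADME assay on HeLa cells (Homo sapiens) for cytotoxicity, read by MTT assay, with a stated time of 72 h; on this read-out higher numbers stand for lower toxicity in this test and lower numbers for higher toxicity in this test:
compound 1 `Nc1sc2c(c1-c1nc3cc(Cl)ccc3s1)CCCC2` gives 107 ug/mL.
compound 2 `C(=N/c1sc2c(c1-c1nc3ccccc3s1)CCCC2)\c1ccccc1` gives 333 ug/mL.

Compound 2 stands highest of these two numbers; its nearest neighbour is compound 1, and that gap lies beyond the usual scatter. Compound 3 `Oc1ccccc1/C=N/c1sc2c(c1-c1nc3ccccc3s1)CCCC2` differs from compound 2 by hydroxy in place of hydrogen on an aromatic carbon. Going by the values given here, no step between measured compounds shows what such a change does here, so in this assay a step no larger than the scatter is expected, in no particular direction. Compound 3 is therefore expected to give 250 ug/mL, with a range from 100 ug/mL to 600 ug/mL, an expected step of a 1.3-fold lower number from compound 2 to compound 3 (0.12 log units; within the scatter).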

Compound 3, half-maximal cytotoxic concentration: 122 ug/mL
Beside the measured number, compound 3's estimate is 2.0-fold (0.31 log units) above it; low and high end bracket the measured number.
By their numbers in this assay, from the lowest: compounds 1 and 3 (each within the scatter of the next); then compound 2.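

In this assay, the change from phenyl to 2-hydroxyphenyl, on an aromatic carbon ortho to a large group, brings a 2.7-fold lower number from compound 2 to compound 3 (0.44 log units; beyond the scatter) and so moves the read-out toward higher toxicity in this test. This shows that this ring is not indifferent to a small substituent, although this is a single pair of compounds. Nothing available accounts for the shift.

On these data alone, a methoxy group or an amine at this carbon remains open. So does whether hydroxy would act the same way at another carbon of this ring.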